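Thiazole alkyne series: amide to urea at the carbonyl

This account rests on a few compounds, and the source may have more. Where it says the series, first, only, none or still open, it means among the compounds named here.

Within the data shown here, compound 2 `CC1CC(C(=O)N2CCc3nc(C#Cc4ccccc4)sc3C2)C1` is the only member with a number in an assay on HEK293 cells for positive allosteric modulation of metabotropic glutamate receptor 5 (Homo sapiens), read by FLIPR, with a stated time of 1 h (a lower number here means that less compound is needed, a higher number that more compound is needed for the effect), where compound 2 gives 81 nM. Compound 1 `CN1CCc2nc(C#Cc3cccc(F)c3)sc2C1` reaches only the limit of the assay, > 10000 nM in this assay (the limit of > 10000 nM in this assay, at which 1 of the 2 values shown sits). Among the measured compounds shown here, no single-point step between measured compounds exists here.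

Compound 3 `O=C(N1CCCCC1)N1CCc2nc(C#Cc3ccccc3)sc2C1` differs from compound 2 by piperidin-1-yl in place of 3-methylcyclobutyl on a carbonyl carbon. No measured step of this kind is shown, so the expectation is a small shift toward more compound needed, possibly no more than the scatter: the step from compound 2 to compound 3 is estimated at a 2.5-fold higher number from compound 2 to compound 3 (0.39 log units; beyond the scatter). Compound 3 is therefore expected at 200 nM in this assay, within 50 nM to 800 nM.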

Compound 3, half-maximal effective concentration: 75 nM
For compound 3 the middle estimate is 2.7-fold (0.43 log units) above the measured one; measured number inside the range.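

Among these compounds, this is the first single-place step, and it reads a 1.1-fold lower number from compound 2 to compound 3 (0.03 log units; within the scatter) in this assay. At this position on the carbonyl carbon, piperidin-1-yl therefore stands level with 3-methylcyclobutyl, and the change from (3-methylcyclobutyl)carbonyl to (piperidin-1-yl)carbonyl, amide to urea, costs nothing measurable here. No measured property shown offers a reason for this flat step.

Open, on these data alone, is whether morpholin-4-yl or dimethylamino on the same carbonyl carbon holds this level. Also open, as far as these compounds go, is whether an ethoxy group there, giving a carbamate, does the same.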